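The compounds below may be only part of what the source reports. "The series", "measured", "known", "first", "only" and "open" are said of these compounds alone.

Measured in an ADME assay on liver for metabolic stability, with Liver microsome (Homo sapiens) as the target, read by LC-MS, using microsomes (a lower number here means slower removal, a higher number faster removal of the compound), so far:
- compound 1 `CC1(C[C@@H](O)C(=O)N2N=CC[C@H]2C(=O)NCc2cc(Cl)ccc2-n2cnnn2)CC1` gives < 12 mL.min-1.g-1 as a limit
- compound 2 `CCCC[C@@H](O)C(=O)N1N=CC[C@H]1C(=O)NCc1cc(Cl)ccc1-n1cnnn1` gives < 12 mL.min-1.g-1 as a limit

In this assay compound 2 stands at < 12 mL.min-1.g-1 and this is a limit, not a number. The evidence so far is the limit of < 12 mL.min-1.g-1 in this assay, at which 2 of the 2 values shown sit, and nothing more.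

Compound 3 `O=C(NCc1cc(Cl)ccc1-n1cnnn1)[C@@H]1CC=NN1C(=O)[C@H](O)C1CCCCC1` has cyclohexyl in place of butyl on a saturated chain carbon bound to a carbonyl carbon and an oxygen on a saturated carbon.

Among the measured compounds shown here, the one measured step is a step that the two limits leave unreadable from compound 1 to compound 2 and offers no size to carry over. The step expected in this assay is a number no lower from compound 2 to compound 3 (the limit leaves the size open) and none beyond the scatter is foreseen. For compound 3 the expected value is 12 mL.min-1.g-1 with an estimated range from 6 mL.min-1.g-1 to 28 mL.min-1.g-1.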

Compound 3, intrinsic clearance in microsomes: 63 mL.min-1.g-1
Compound 3: the middle estimate sits 5.3-fold (0.72 log units) below what was measured, outside the stated range (above it).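

In this assay, the group on the saturated chain carbon bound to a carbonyl carbon and an oxygen on a saturated carbon does matter: cyclohexyl gives an at least 5.2-fold higher number from compound 2 to compound 3 (0.72 log units; beyond the scatter) and an at least 5.2-fold higher number from compound 1 to compound 3 (0.72 log units; beyond the scatter). Among the compounds shown here, the step between the two earlier compounds cannot be read, so these are the first readable steps at this position. Their size is open-ended, as their lower end is a limit and not a number: the limit of < 12 mL.min-1.g-1 in this assay, at which 2 of the 3 values shown sit.

Cyclohexyl differs from butyl in both ring and carbon count, and the two remain unseparated. A cyclopentyl or a hexyl group at this position would bear on that.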